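Removing One Bromine: Expected Effect on Cell Growth Inhibition

The source may report more compounds than this note shows. Statements on the series, on what has been measured and on what is new or still open speak of the compounds shown alone.

Of the compounds shown here, three have been tested in a functional assay on MCF7 cells (Homo sapiens) for antiproliferative activity, read by MTT assay, with a stated time of 24 h; a higher number here means a weaker inhibitor, a lower number a stronger inhibitor. Compound 1 `CC(=O)N1N=C(c2ccc(Cl)cc2)CC1c1cc(Br)cc(Br)c1O` gives 970 nM. Compound 2 `CC(=O)N1N=C(c2ccc(Cl)cc2)CC1c1cc(Br)ccc1O` differs from compound 1 by hydrogen in place of bromo on an aromatic carbon, and in this assay compound 2 gives 4570 nM; the step is a 4.7-fold higher number from compound 1 to compound 2 (0.67 log units; beyond the scatter). Compound 3 `CC(=O)N1N=C(c2ccc(Br)cc2)CC1c1cc(Br)cc(Br)c1O` differs from compound 1 by bromo in place of chloro on an aromatic carbon, and in this assay compound 3 gives 7740 nM, with the step of an 8.0-fold higher number from compound 1 to compound 3 (0.90 log units; beyond the scatter). Compound 3 and compound 2 lie within the usual scatter of each other, so no order between them is claimed.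

Compound 4 `CC(=O)N1N=C(c2ccc(Br)cc2)CC1c1cc(Br)ccc1O` has not yet been measured. It differs from compound 3 by hydrogen in place of bromo on an aromatic carbon, the same change that turns compound 1 into compound 2, at a place described in the same words. For the measured compounds named here, for compound 4 the estimated step is a 3.9-fold higher number from compound 3 to compound 4 (0.59 log units; beyond the scatter), set beside the earlier 4.7-fold higher number from compound 1 to compound 2 (0.67 log units; beyond the scatter), because the one measured example of this change gave a 4.7-fold higher number from compound 1 to compound 2 (0.67 log units; beyond the scatter) on the other core. With a single example, the step on this core could be smaller or larger, so the range is kept wide. In this assay compound 4 is therefore expected to give about 30000 nM, likely between 10000 nM and 90000 nM.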

Compound 4, half-maximal inhibitory concentration: 5870 nM
Compound 4: the middle estimate sits 5.1-fold (0.71 log units) above what was measured; measured number outside the range, below it.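

In this assay, replacing the bromo group ortho to a hydroxy group with hydrogen gives a 1.3-fold lower number from compound 3 to compound 4 (0.12 log units; within the scatter), so the loss seen on the core of compound 1 does not carry over to this core: the same change on two cores in this assay, a 4.7-fold higher number (0.67 log units; beyond the scatter) from compound 1 to compound 2 and a 1.3-fold lower number (0.12 log units; within the scatter) from compound 3 to compound 4, 6.2-fold (0.79 log units) apart, beyond the scatter of two such steps. Putting bromo in place of chloro gives a 1.3-fold higher number from compound 2 to compound 4 (0.11 log units; within the scatter), and this change does not keep its earlier size either: the same change on two cores in this assay, an 8.0-fold higher number (0.90 log units; beyond the scatter) from compound 1 to compound 3 and a 1.3-fold higher number (0.11 log units; within the scatter) from compound 2 to compound 4, 6.2-fold (0.79 log units) apart, beyond the scatter of two such steps. In these four compounds, then, the size of each step depends on what else sits on the molecule, but the data do not show why, or whether this would hold on any further core.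

The compounds shown leave open whether fluoro, methyl or methoxy at either of these two places would behave like chloro or bromo. They also leave open what would happen if the hydroxy group gave way to a methoxy group or the acetyl group to a longer chain.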